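The source may hold more compounds than are shown below. What is called first, only, known or untested is meant among the compounds shown, and "the series" means these compounds.

In a functional assay on HeLa cells (Homo sapiens) for inhibition, read by MTT assay, with a stated time of 48 h (on this read-out higher numbers stand for weaker inhibition of growth and lower numbers for stronger inhibition of growth), three related compounds have been measured so far. Compound 1 `COc1ccc(C2=NN(C(=O)c3cccnc3)C(c3cn(C)c4ccc(Br)cc34)C2)cc1OC` gives 2090 nM, compound 2 `COc1ccc2c(c1)c(C1CC(c3ccccc3)=NN1C(=O)c1ccc(OC)nc1)cn2C` gives 1100 nM and compound 3 `COc1ccc2c(c1)c(C1CC(c3ccc(F)cc3)=NN1C(=O)c1ccc(OC)nc1)cn2C` gives 410 nM. That last number is the lowest of the three, and its gap to each of the other two lies beyond the scatter.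

The next compound, compound 4 `COc1ccc(C2=NN(C(=O)c3ccc(OC)nc3)C(c3cn(C)c4ccc(OC)cc34)C2)cc1`, departs from compound 3 in one place: methoxy in place of fluoro on an aromatic carbon. This puts methoxy in place of fluoro on an aromatic carbon, turning 4-fluorophenyl into 4-methoxyphenyl.

Among the compounds with values here, one measured step bears on this change: a 2.7-fold lower number from compound 2 to compound 3 (0.43 log units; beyond the scatter), a modest step that came with fluoro in place of hydrogen on an aromatic carbon. Within the data shown here, no measured step isolates methoxy in place of fluoro, and compound 1 differs from compound 3 in several places. The expectation is therefore for no change beyond the scatter, with a lean towards a higher number. The expected step is a 1.5-fold higher number from compound 3 to compound 4 (0.17 log units; within the scatter). For compound 4 the estimated value is 600 nM, with an expected range from 200 nM to 1800 nM.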

Compound 4, concentration for 50% growth inhibition: 180 nM
The estimate for compound 4 lay 3.3-fold (0.52 log units) above the measured number; the measured number lies below the stated range.
By their numbers in this assay, from the lowest: compound 4; then compound 3; then compounds 2 and 1 (each within the scatter of the next).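

In this assay the change from 4-fluorophenyl to 4-methoxyphenyl gives a 2.3-fold lower number from compound 3 to compound 4 (0.36 log units; beyond the scatter) and so shows that the number at this place, para to a large group, can still fall once fluoro is there. Set against hydrogen on the same carbon, methoxy gives a 6.1-fold lower number from compound 2 to compound 4 (0.79 log units; beyond the scatter) while fluoro gives a 2.7-fold lower number from compound 2 to compound 3 (0.43 log units; beyond the scatter) and both replacements of hydrogen therefore lower the number in this series. Nothing available explains why methoxy goes with the lower number here.

As far as these compounds go, whether a chloro, an ethoxy or an amine on this carbon would lower the number further stays open. Also open, from the compounds shown here alone, is whether methoxy in place of fluoro brings a similar step on a core carrying other groups, such as the bromo of compound 1.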